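Removing a Chloro Group: Phenoxy Ring Versus Core Ring

The compounds below may be only part of what the source reports. "The series", "measured", "known", "first", "only" and "open" are said of these compounds alone.

Compound 1 `Cc1cc(Oc2ccccc2)c(S(C)(=O)=O)cc1C(=O)N=C(N)N` gives 10 nM in a functional assay for inhibition of sodium/hydrogen exchanger (Oryctolagus cuniculus); a lower number here means a stronger inhibitor, a higher number a weaker inhibitor.
Compound 2 `Cc1cc(Oc2ccc(Cl)cc2)c(S(C)(=O)=O)cc1C(=O)N=C(N)N` gives 13 nM in this assay.
Compound 3 `CS(=O)(=O)c1cc(C(=O)N=C(N)N)c(Cl)cc1-n1ccnc1` gives 130 nM in this assay.

Compounds 1 and 2 share a core and differ by hydrogen in place of chloro on an aromatic carbon, a step of a 1.3-fold lower number from compound 2 to compound 1 (0.11 log units; within the scatter). Compound 3 has another core; how it differs from the core of compound 2 is not broken down here. Compound 3 shows the highest number of the three, and its gap to compound 2 lies beyond the scatter.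

Compound 4 `CS(=O)(=O)c1cc(C(=O)N=C(N)N)ccc1-n1ccnc1` has not yet been measured. It differs from compound 3 by hydrogen in place of chloro on an aromatic carbon. For the measured compounds named here, this is the same kind of change as the one from compound 2 to compound 1, not the same: there the chloro sat para to a large group on the phenoxy ring, here it sits on the core ring, ortho to a group of 6 heavy atoms, meta to a 1H-imidazol-1-yl group and para to a methylsulfonyl group. The step from compound 3 to compound 4 is expected to be a 1.9-fold higher number from compound 3 to compound 4 (0.28 log units; within the scatter), a cautious guess because the earlier step of a 1.3-fold lower number from compound 2 to compound 1 (0.11 log units; within the scatter) lay within the scatter while the surroundings here are different. Compound 4 is therefore estimated at 250 nM, within 80 nM to 800 nM.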

Compound 4, half-maximal inhibitory concentration: 150 nM
For compound 4 the middle estimate is 1.7-fold (0.22 log units) above the measured one; low and high end bracket the measured number.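

In this assay, replacing chloro with hydrogen on the core ring gave a 1.2-fold higher number from compound 3 to compound 4 (0.06 log units; within the scatter), so compound 3 and compound 4 cannot be told apart. Set beside the same replacement on the phenoxy ring, the two steps agree: the same change on two cores in this assay, a 1.3-fold lower number (0.11 log units; within the scatter) from compound 2 to compound 1 and a 1.2-fold higher number (0.06 log units; within the scatter) from compound 3 to compound 4, 1.5-fold (0.18 log units) apart, within the scatter of two such steps. On these two cores, then, the replacement stays within the scatter and carries over in that limited sense, but two pairs do not show that it would do so on other cores or at other places, nor do they explain the result.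

The compounds shown leave open whether a fluoro group, a methoxy group or an amine in place of the chloro would shift the number on the core of compound 3. Going by these compounds, it also remains open whether an amine or a longer chain in place of the 1H-imidazol-1-yl group would do so.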